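Swapping Chloro for Bromo in a Three-Compound Series

The source may report more compounds than this note shows. Statements on the series, on what has been measured and on what is new or still open speak of the compounds shown alone.

Three compounds share one core and differ only in the group on the outer phenyl ring. Compound 1 `Cc1ccc(-c2nnc(SCCOc3ccc(/C=C4\SC(=O)NC4=O)cc3)[nH]2)cc1` gives 40.3% in a functional assay on the whole organism (strain Wistar) with Rattus norvegicus as the target, with a stated time of 15 days, at a dose of 30 mg/kg by the oral route; on this read-out higher numbers stand for a stronger effect at the one dose given and lower numbers for a weaker effect. In this assay compound 2 `O=C1NC(=O)/C(=C/c2ccc(OCCSc3nnc(-c4ccccc4[N+](=O)[O-])[nH]3)cc2)S1` gives 38.6%. In this assay compound 3 `O=C1NC(=O)/C(=C/c2ccc(OCCSc3nnc(-c4ccc(Cl)cc4)[nH]3)cc2)S1` gives 32.9%. Compound 3 stands at the lowest of the three numbers, yet the steps of a number 5.7 percentage points lower from compound 2 to compound 3 (within the scatter) and a number 7.4 percentage points lower from compound 1 to compound 3 (within the scatter) both lie within the scatter, as does a number 1.7 percentage points lower from compound 1 to compound 2 (within the scatter), so the three values cannot be told apart.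

Compound 4 `O=C1NC(=O)/C(=C/c2ccc(OCCSc3nnc(-c4ccc(Br)cc4)[nH]3)cc2)S1` carries the change (bromo in place of chloro on an aromatic carbon). Within the data shown here, no measured step exchanges one halogen for another; the steps that bear most on it are a number 7.4 percentage points lower from compound 1 to compound 3 (within the scatter), where methyl became chloro, and a number 5.7 percentage points lower from compound 2 to compound 3 (within the scatter), where a 2-nitrophenyl became a 4-chlorophenyl. Both stayed within the scatter, and the change from compound 3 to compound 4 is again a single substituent swap on an aromatic carbon. No step beyond the scatter is therefore expected in this assay. Compound 4 is estimated at 34%, with a range from 24% to 46%. The expected step of a number 1.1 percentage points higher from compound 3 to compound 4 (within the scatter) amounts to essentially no change.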

Compound 4, a percentage reported as activity, at one dose (the size of the read-out at that dose, not a potency): 39.5%
Beside the measured number, compound 4's estimate is 5.5 percentage points below it; the range from low to high includes it.
By their numbers in this assay, from the lowest: compounds 3, 2, 4 and 1 (each within the scatter of the next).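

In this assay, among these compounds, bromo in place of chloro on an aromatic carbon, para to a large group, gives a number 6.6 percentage points higher from compound 3 to compound 4 (within the scatter), and this is the first direct exchange of one halogen for another. The 4-bromophenyl compound also cannot be told apart from the other two: the exchange for 2-nitrophenyl reads a number 0.9 percentage points higher from compound 2 to compound 4 (within the scatter) and the exchange for methyl reads a number 0.8 percentage points lower from compound 1 to compound 4 (within the scatter), so all the groups seen so far on this outer ring leave the read-out within the scatter at the one dose given. No measured property of these groups is available to set beside these numbers.

From the compounds shown here alone, what stays open is whether a group of another kind on the same ring, such as an amine, a carboxylic acid or a longer alkyl chain, would give a step beyond the scatter. Going by these compounds, the read-out at a single dose also gives the size of the effect and no potency, so whether the four compounds would separate at another dose in this assay remains unknown.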